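This account rests on a few compounds, and the source may have more. Where it says the series, first, only, none or still open, it means among the compounds named here.

Values in a functional assay on MCF7 cells (Homo sapiens) for antiproliferative activity, read by MTT assay, with a stated time of 72 h; on this read-out lower numbers stand for stronger inhibition and higher numbers for weaker inhibition:
- Compound 1 `C=C(Br)C(=O)Nc1ccc2c(c1)/C(=C\c1ccsc1)C(=O)N2`: 2100 nM
- Compound 2 `C=C(Br)C(=O)Nc1ccc2c(c1)/C(=C\c1cccs1)C(=O)N2`: 2300 nM

Within the data shown here, compound 1 stands level with compound 2, the only other measured compound, and the step between them is a 1.1-fold higher number from compound 1 to compound 2 (0.04 log units; within the scatter). Compound 3 `C=C(Br)C(=O)Nc1ccc2c(c1)/C(=C/c1ccsc1)C(=O)N2` keeps the structure of compound 1 except for one feature: the two compounds have the same atoms and bonds and differ only in configuration as drawn: 1 of 1 stereo elements differ; a double bond is drawn E in compound 1 and Z in compound 3. Among the measured compounds shown here, the one measured step exchanges thiophen-3-yl for thiophen-2-yl and leaves this configuration untested, so the data set no direction. No change beyond the scatter is therefore expected in this assay, though the uncertainty is wide. The expected step is a 1.2-fold higher number from compound 1 to compound 3 (0.08 log units; within the scatter). For compound 3 the estimate is 2500 nM, with an expected range of 900 nM to 7000 nM.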

Compound 3, half-maximal inhibitory concentration: 2800 nM
The estimate for compound 3 lay 1.1-fold (0.05 log units) below the measured number; measured number inside the range.
By their numbers in this assay, from the lowest: compounds 1, 2 and 3 (each within the scatter of the next).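

In this assay, the configuration of the double bond, which the earlier pair left untested, now has a reading: a 1.3-fold higher number from compound 1 to compound 3 (0.12 log units; within the scatter). The E and Z forms of this thiophen-3-yl compound therefore cannot be told apart in this assay. The comparison speaks to configuration alone: the fact that compounds 1 and 3 differ only in the configuration as drawn.

On these data alone, it remains open whether the same would hold with thiophen-2-yl, as in compound 2. As far as these compounds go, it is also open whether configuration would count for as little with a phenyl or a pyridin-3-yl group in place of the thiophene.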